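Methoxy for hydrogen on the 4-hydroxyphenyl of compound 2

The source may report more compounds than this note shows. Statements on the series, on what has been measured and on what is new or still open speak of the compounds shown alone.

Compound 1 `COc1ccc2c(c1)nc(-c1c(O)cc(O)cc1O)c(=O)n2CC(=O)O` gives 53.7% in a functional assay, with a stated time of 240 min, tested at 50 uM; on this read-out higher numbers stand for a stronger effect at the one concentration tested and lower numbers for a weaker effect. Within the data shown here, compound 2 `COc1ccc2c(c1)nc(/C=C/c1ccc(O)cc1)c(=O)n2CC(=O)O` gives 27.6% in this assay, the lowest of the two numbers so far; its gap to compound 1 lies beyond the scatter. Compound 3 `COc1ccc2c(c1)nc(/C=C/c1ccc(O)c(OC)c1)c(=O)n2CC(=O)O` is not yet measured. It differs from compound 2 by methoxy in place of hydrogen on an aromatic carbon, read one bond further out as 4-hydroxyphenyl to 4-hydroxy-3-methoxyphenyl. Among the measured compounds shown here, no measured pair shows this change. The step expected in this assay is small, with no clear direction. The estimate for compound 3 is 31%, with a range of 15% to 50%. The expected step of a number 3.4 percentage points higher from compound 2 to compound 3 (within the scatter) stays within the scatter.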

Compound 3, a percentage reported as activity, at one concentration (the size of the read-out at that concentration, not a potency): 61.4%
Compound 3: the middle estimate sits 30.4 percentage points below what was measured, outside the stated range (above it).
By their numbers in this assay, from the lowest: compound 2; then compounds 1 and 3 (each within the scatter of the next).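

Methoxy in place of hydrogen on the aromatic carbon ortho to the hydroxy group gives a number 33.8 percentage points higher from compound 2 to compound 3 (beyond the scatter) in this assay and so shows that this position of the 4-hydroxyphenyl responds to substitution. This reading rests on a single pair, 4-hydroxyphenyl to 4-hydroxy-3-methoxyphenyl. Nothing at hand offers an explanation for the size of this step. From the compounds shown here alone, whether ethoxy or a chlorine atom on the same carbon gives a similar step remains open. Also open, going by these compounds, is whether the step persists when an amine replaces the hydroxy group.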